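Replacing the dihydroxyphenyl end of a caffeate ester

The source may report more compounds than this note shows. Statements on the series, on what has been measured and on what is new or still open speak of the compounds shown alone.

Within the data shown here, compound 1 `CS(=O)(=O)c1ccc(-c2nc(SCCCOC(=O)/C=C/c3ccc(O)c(O)c3)nn2-c2ccc(Br)cc2)cc1` is one of two compounds measured in a functional assay on B16-F10 cells (Mus musculus) for antiproliferative activity, read by MTT assay, with a stated time of 72 h (on this read-out higher numbers stand for weaker inhibition and lower numbers for stronger inhibition), where compound 1 gives 13100 nM, the highest of the two numbers. Its nearest neighbour is compound 2 `CS(=O)(=O)c1ccc(-c2nc(SCCCOC(=O)/C=C/c3ccc(O)c(O)c3)nn2-c2ccc(F)cc2)cc1`, which in this assay gives 10400 nM; the step of a 1.3-fold lower number from compound 1 to compound 2 (0.10 log units; within the scatter) is within the scatter. Compound 3 `CS(=O)(=O)c1ccc(-c2nc(SCCCOC(=O)/C=C/c3ccccc3)nn2-c2ccc(Br)cc2)cc1` has not been measured. It differs from compound 1 by phenyl in place of 3,4-dihydroxyphenyl on a double-bonded chain carbon bound to a double-bonded chain carbon, that is, the 3,4-dihydroxyphenyl group with its two hydrogen-bond donors and two acceptors becomes a bare phenyl. Among the measured compounds shown here, no measured step touches this part of the molecule; the only step at hand, from compound 1 to compound 2, concerns a halogen on a different ring and lies within the scatter, so it gives no guidance on the size or direction of this change. On this basis compound 3 is expected to give 25000 nM in this assay, with a range of 8000 nM to 80000 nM, an expected step of a 1.9-fold higher number from compound 1 to compound 3 (0.28 log units; within the scatter).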

Compound 3, half-maximal inhibitory concentration: 19400 nM
Estimate against measurement, compound 3: 1.3-fold (0.11 log units) above, within the range that was stated.
By their numbers in this assay, from the lowest: compounds 2, 1 and 3 (each within the scatter of the next).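

In this assay the step of a 1.5-fold higher number from compound 1 to compound 3 (0.17 log units; within the scatter) lies within the scatter, so the bare phenyl group cannot be told apart from the 3,4-dihydroxyphenyl group at this place on a double-bonded chain carbon. The earlier pair spoke only of a halogen on another ring; this pair shows that, with bromo in place, the hydrogen-bond donors and acceptors counted on the 3,4-dihydroxyphenyl group can go without a change that this read-out can resolve. No accompanying measurement bears on why this is so.

It stays open whether the same exchange would read alike with fluoro in place of bromo, since only one such pair is shown. Also open, on these data alone, is whether a methoxy group, an amine or a carboxylic acid on this phenyl ring would move the number beyond the scatter.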